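A few compounds are considered here, and "the series" means these few. Any claim that something is new, unique, unknown or untested is made for them only; others in the source may bear on it.

Compound 1 `CC1=C(/C=C/C(=O)/C=C/c2ccc(Cl)cc2)C(C)(C)CCC1`: 90600 nM
Compound 2 `CC1=C(/C=C/C(=O)/C=C/c2ccc(C)cc2)C(C)(C)CCC1`: 44100 nM

In a functional assay on Hep cells (Homo sapiens) for cytotoxicity, read by sulforhodamine B assay, with a stated time of 48 h (on this read-out higher numbers stand for weaker inhibition and lower numbers for stronger inhibition), compound 1 gives 90600 nM, while compound 2 gives 44100 nM, the lower of the two numbers. For the measured compounds named here, the single measured step, a 2.1-fold lower number from compound 1 to compound 2 (0.31 log units; beyond the scatter), is modest and is the only guide available. Compound 3 `CC1=C(/C=C/C(=O)/C=C/c2ccc([N+](=O)[O-])cc2)C(C)(C)CCC1` differs from compound 2 by nitro in place of methyl on an aromatic carbon. Going by the values given here, no measured step involves a nitro group, so the direction of this change cannot be read from the numbers at hand, and the expected step is a 1.4-fold higher number from compound 2 to compound 3 (0.13 log units; within the scatter), none beyond the scatter. For compound 3 the estimate is 60000 nM, within a range from 25000 nM to 150000 nM.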

Compound 3, half-maximal inhibitory concentration: 55500 nM
Beside the measured number, compound 3's estimate is 1.1-fold (0.03 log units) above it, and the stated range covers the measured number.
By their numbers in this assay, from the lowest: compounds 2, 3 and 1 (each within the scatter of the next, the first and the last beyond it).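

In this assay, nitro on this aromatic carbon cannot be told apart from either earlier group: the swap for methyl gives a 1.3-fold higher number from compound 2 to compound 3 (0.10 log units; within the scatter) and the swap for chloro gives a 1.6-fold lower number from compound 1 to compound 3 (0.21 log units; within the scatter). So a group with more heavy atoms than methyl, carrying hydrogen-bond acceptors, can sit at this position without a step beyond the scatter. No measurement here bears on the reason for this result. Still open, on these data alone, is how an amine or a carboxylic acid would behave at this carbon, and whether changes elsewhere on the shared core would move the number further.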